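Piperazine nitrogen substituent: aryl to benzyl step

The source may report more compounds than this note shows. Statements on the series, on what has been measured and on what is new or still open speak of the compounds shown alone.

Compound 2 `N#Cc1cccc(COc2ccc(-c3cc(CN4CCN(c5ccc(F)cc5)CC4)no3)cc2)c1` gives 1500 nM in a functional assay on Huh-7 cells (Homo sapiens) for antiproliferative activity, read by sulforhodamine B assay, with a stated time of 72 h; a higher number here means a weaker inhibitor, a lower number a stronger inhibitor. The only comparator, compound 1 `N#Cc1cccc(COc2ccc(-c3cc(CN4CCN(c5ccc(C(F)(F)F)cn5)CC4)no3)cc2)c1`, gives 1700 nM in this assay, and the step of a 1.1-fold lower number from compound 1 to compound 2 (0.05 log units; within the scatter) leaves the two values indistinguishable. Compound 3 `N#Cc1cccc(COc2ccc(-c3cc(CN4CCN(Cc5ccccc5F)CC4)no3)cc2)c1` is unmeasured; it differs from compound 2 by 2-fluorobenzyl in place of 4-fluorophenyl on an amine nitrogen in a ring. Among the measured compounds shown here, the single measured step bears on it only loosely: from compound 1 to compound 2 one aromatic group on the same ring nitrogen was exchanged for another aromatic group without a shift beyond the scatter, whereas the change to compound 3 replaces the aromatic group on that nitrogen by a benzyl group, a kind of change no measured pair covers. For the measured compounds named here, with one flat step as the only guide, the expectation for compound 3 in this assay is no shift beyond the scatter, with a wide range allowed for the untested kind of change. Compound 3 is therefore estimated at 1800 nM, within 600 nM to 5500 nM. The implied step a 1.2-fold higher number from compound 2 to compound 3 (0.08 log units; within the scatter) is expected to be small.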

Compound 3, half-maximal inhibitory concentration: 2400 nM
Compound 3: the middle estimate sits 1.3-fold (0.12 log units) below what was measured; measured number inside the range.
By their numbers in this assay, from the lowest: compounds 2, 1 and 3 (each within the scatter of the next).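

In this assay the measured steps now include a benzyl group on the amine nitrogen in the ring, a kind of change the aryl-to-aryl step did not cover, and it stays within the scatter against both aryl comparators (a 1.6-fold higher number from compound 2 to compound 3 (0.20 log units; within the scatter); a 1.4-fold higher number from compound 1 to compound 3 (0.15 log units; within the scatter)). Across these three compounds, 4-fluorophenyl, 5-(trifluoromethyl)pyridin-2-yl and 2-fluorobenzyl on this nitrogen therefore give values that cannot be told apart, even though the 2-fluorobenzyl group has 8 heavy atoms against the 7 of 4-fluorophenyl and the aromatic ring no longer sits directly on the nitrogen. No measurement available here accounts for this flat reading at the position.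

The 2-fluorobenzyl group differs from 4-fluorophenyl in two respects at once, so the compounds shown do not separate the effect of the added carbon from that of the fluorine placement, which unsubstituted benzyl and 4-fluorobenzyl would address. They also leave open whether the flat reading extends to a longer chain such as phenethyl, to a benzoyl group with its carbonyl on this nitrogen, or to a small alkyl group such as methyl.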